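Changing the Aromatic Group on a Shared Core

The source may report more compounds than this note shows. Statements on the series, on what has been measured and on what is new or still open speak of the compounds shown alone.

Of the compounds shown here, three with a shared core have been measured in a functional assay on HepG2 cells (Homo sapiens) for cytotoxicity, read by MTT assay, with a stated time of 48 h; on this read-out higher numbers stand for weaker inhibition and lower numbers for stronger inhibition. Compound 1 (`Cc1ncc([N+](=O)[O-])n1CCSc1nnc(-c2ccccc2)o1`) gives 17500 nM, compound 2 (`Cc1ncc([N+](=O)[O-])n1CCSc1nnc(-c2ccccc2N)o1`) gives 4500 nM and compound 3 (`Cc1cccc(-c2nnc(SCCn3c([N+](=O)[O-])cnc3C)o2)c1O`) gives 8700 nM. Compound 3 cannot be separated from either of the others, as the data show a 2.0-fold lower number from compound 1 to compound 3 (0.30 log units; within the scatter) and a 1.9-fold higher number from compound 2 to compound 3 (0.29 log units; within the scatter).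

Compound 4 (`Cc1ncc([N+](=O)[O-])n1CCSc1nnc(-c2ccc(N)nc2)o1`) has 6-aminopyridin-3-yl in place of 2-hydroxy-3-methylphenyl on an aromatic carbon.

Going by the values given here, two measured steps bear on this change. Placing amino in place of hydrogen on an aromatic carbon gave a 3.9-fold lower number from compound 1 to compound 2 (0.59 log units; beyond the scatter), a modest step and the only one beyond the scatter. Compound 4 also carries an amino group, though on a different ring. Exchanging one substituted aromatic group for another, as in 2-hydroxy-3-methylphenyl in place of 2-aminophenyl, gave a 1.9-fold higher number from compound 2 to compound 3 (0.29 log units; within the scatter). Among the compounds with values here, no measured compound has a hetero atom in this aromatic ring, so that part of the change remains untested.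

A step beyond the scatter is therefore not expected, and no direction can be firmly assigned. The expected outcome is a 1.2-fold lower number from compound 3 to compound 4 (0.09 log units; within the scatter). Compound 4 is estimated at 7000 nM, with an expected range of 2500 nM to 20000 nM.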

Compound 4, half-maximal inhibitory concentration: 9400 nM
Estimate against measurement, compound 4: 1.3-fold (0.13 log units) below; the measured number falls inside the stated range.
By their numbers in this assay, from the lowest: compounds 2, 3, 4 and 1 (each within the scatter of the next, the first and the last beyond it).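

In this assay, 6-aminopyridin-3-yl in place of 2-hydroxy-3-methylphenyl gives a 1.1-fold higher number from compound 3 to compound 4 (0.03 log units; within the scatter), so the first ring with a hetero atom at this position cannot be told apart from the carbon ring of compound 3. An amino group on the ring also does not carry the same result across both ring types: the step from 2-aminophenyl to 6-aminopyridin-3-yl is a 2.1-fold higher number from compound 2 to compound 4 (0.32 log units; beyond the scatter), a modest change, while the comparison with the unsubstituted phenyl gives a 1.9-fold lower number from compound 1 to compound 4 (0.27 log units; within the scatter), so compound 4 does not separate from compound 1 as compound 2 does. No supporting data are available to explain these differences.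

The compounds shown leave open whether the ring nitrogen or the placement of the amino group accounts for the gap between compound 2 and compound 4, a question that a plain pyridin-3-yl or a 4-aminophenyl at the same position would help to answer. Also open, as far as these compounds go, is how a group of another kind, such as a carboxylic acid or a methoxy group, would behave at this position on the shared core.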